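The source may report more compounds than this note shows. Statements on the series, on what has been measured and on what is new or still open speak of the compounds shown alone.

Two measured compounds set the scene. Compound 1, `Cn1ccc2c(Oc3ccc(NC(=O)c4cn(-c5ccc(Cl)cc5)c5ccccc5c4=O)cc3F)ccnc21`, gives 250 nM in a functional assay on A549 cells (Homo sapiens) for inhibition, read by MTT assay, with a stated time of 72 h; a lower number here means a stronger inhibitor, a higher number a weaker inhibitor. Compound 2, `O=C(Nc1ccc(Oc2ccnc3[nH]ccc23)c(F)c1)c1cn(-c2ccccc2)c2ccccc2c1=O`, gives 420 nM in this assay. Compound 2 therefore stands with the higher of the two numbers, but its gap to compound 1 is within the usual scatter of repeated measurements, so the two readings cannot be told apart with confidence. Among the measured compounds shown here, the two compounds differ in more than one place, so no single step connects them.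

Compound 3, `O=C(Nc1ccc(Oc2ccnc3[nH]ccc23)c(F)c1)c1cn(-c2ccc(Cl)cc2)c2ccccc2c1=O`, is the next candidate. It is built from compound 2 by one change: chloro in place of hydrogen on an aromatic carbon. For the measured compounds named here, the same chloro group sits on the phenyl ring of compound 1, which has the lower of the two known numbers.

Going by the values given here, no measured pair shows this change on its own, so the size of the step is open. Given that compound 1 with 250 nM carries the chloro group, a small move toward a lower number is expected from compound 2 to compound 3, and that step is estimated as a 1.4-fold lower number from compound 2 to compound 3 (0.15 log units; within the scatter), though it may well remain within the scatter. Compound 3 is expected to give 300 nM in this assay, within a range of 120 nM to 750 nM.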

Compound 3, half-maximal inhibitory concentration: 320 nM
Compound 3: middle estimate off by 1.1-fold (0.03 log units), on the low side, and the stated range covers the measured number.
By their numbers in this assay, from the lowest: compounds 1, 3 and 2 (each within the scatter of the next).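

The phenyl to 4-chlorophenyl change now has a pair of its own: in this assay, chloro in place of hydrogen, para to a large group, gives a 1.3-fold lower number from compound 2 to compound 3 (0.12 log units; within the scatter), so the readings with and without the chloro group cannot be told apart. Compound 3 also links to compound 1 through a single change elsewhere in the molecule, hydrogen in place of methyl on an aromatic nitrogen, which gives a 1.3-fold higher number from compound 1 to compound 3 (0.11 log units; within the scatter), so neither of the two single changes shown moves the number beyond what repeated measurements could produce. No measurement is available that could explain either small step.

The compounds shown leave open whether any group on that aromatic carbon can shift the number beyond the scatter, for example a methoxy group, an amine or a carboxylic acid in place of the chloro group. Going by these compounds, it is equally open how a longer chain, such as ethyl or propyl, would read on the aromatic nitrogen that carries hydrogen in compound 3 and methyl in compound 1.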